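A few compounds are considered here, and "the series" means these few. Any claim that something is new, unique, unknown or untested is made for them only; others in the source may bear on it.

Three related compounds have so far been tested in a functional assay on KYSE-70 cells for antiproliferative activity against KYSE-70 cell line (Homo sapiens), read by MTT assay, with a stated time of 72 h; on this read-out lower numbers stand for stronger inhibition and higher numbers for weaker inhibition. Compound 1 `O=C(Nc1cccc(C(F)(F)F)c1)c1cc(=O)[nH]c2cc(Br)ccc12` gives > 20000 nM, which is a limit of the assay and not a number. Compound 2 `COc1ccc2c(C(=O)Nc3cc(F)cc(F)c3)cc(=O)[nH]c2n1` gives > 20000 nM, and this too is a limit. Compound 3 `CC(C)(C)c1ccc(-c2ccc3c(C(=O)Nc4cccc(F)c4)cc(=O)[nH]c3c2)cc1` gives > 20000 nM, again a limit and not a number. Compound 3 therefore stands where the whole set stands, and the record reads: the limit of > 20000 nM in this assay, at which 3 of the 3 values shown sit.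

Compound 4 `O=C(Nc1cccc(F)c1)c1cc(=O)[nH]c2cc(-c3ccsc3)ccc12` has not yet been measured. It keeps the shared core of compound 3 and carries thiophen-3-yl in place of 4-(tert-butyl)phenyl on an aromatic carbon.

Among the compounds with values here, no step between measured compounds exists in this set, so no size of change can be carried over to this replacement. In this assay the expectation is therefore for no step beyond the scatter, with a modest move toward stronger inhibition as the only other outcome thought plausible. That expectation rests on compound 3, whose > 20000 nM is a limit. The expected step is an at least 1.1-fold lower number from compound 3 to compound 4 (0.04 log units; that floor lies within the scatter). A reported limit is as likely as a number. For compound 4 the estimated value is 18000 nM, with an expected range from 6000 nM to 40000 nM.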

Compound 4, half-maximal inhibitory concentration: 5100 nM
Estimate against measurement, compound 4: 3.5-fold (0.55 log units) above, and the stated range ends above it.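

In this assay, within the data shown here, the aromatic carbon that lies meta to a fused ring and para to a fused ring proves able to change the read-out: placing thiophen-3-yl there in place of 4-(tert-butyl)phenyl gives an at least 3.9-fold lower number from compound 3 to compound 4 (0.59 log units; beyond the scatter) and yields the first true number in the set. Compound 3 gives > 20000 nM, which is a limit of the assay and not a number, so the step has a floor and no upper bound. The earlier compounds shown here could not show this, because they offered no number to compare: the limit of > 20000 nM in this assay, at which 3 of the 4 values shown sit.

This one step does not separate the loss of the tert-butyl group from the change of a six-membered aromatic ring of carbon only to a five-membered one holding sulfur, and plain phenyl or furan-3-yl on the same carbon would be needed to tell these apart. The compounds shown also leave open how an amine, a carboxylic acid or a longer chain at this carbon would read in this assay.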